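The source may hold more compounds than are shown below. What is called first, only, known or untested is meant among the compounds shown, and "the series" means these compounds.

In a functional assay on HT-29 cells (Homo sapiens) for cytotoxicity, read by MTT assay, with a stated time of 72 h (on this read-out higher numbers stand for weaker inhibition and lower numbers for stronger inhibition), compound 1 `O=C(CN1CCN(c2nnc(Cc3ccccc3)c3ccccc23)CC1)Nc1ccc(F)c(C(F)(F)F)c1` gives 4590 nM. Compound 2 `COc1ccc(NC(=O)CN2CCN(c3nnc(Cc4ccccc4)c4ccccc34)CC2)cc1OC` gives 145000 nM, and compound 3 `O=C(CN1CCN(c2nnc(Cc3ccccc3)c3ccccc23)CC1)Nc1ccc(Br)cc1` gives 60200 nM, the second highest of the three numbers. Compound 4 `Cc1cccc(Cl)c1NC(=O)CN1CCN(c2nnc(Cc3ccccc3)c3ccccc23)CC1` differs from compound 3 in one place: 2-chloro-6-methylphenyl in place of 4-bromophenyl on an amide-type nitrogen. This places 2-chloro-6-methylphenyl where 4-bromophenyl stood on an amide-type nitrogen. Three measured steps changed the group at this same nitrogen. Two are large, a 32-fold higher number from compound 1 to compound 2 (1.50 log units; beyond the scatter) and a 13-fold higher number from compound 1 to compound 3 (1.12 log units; beyond the scatter), and both leave the 4-fluoro-3-(trifluoromethyl)phenyl group of compound 1. Going by the values given here, compound 4 lacks that group too, which makes the modest 2.4-fold lower number from compound 2 to compound 3 (0.38 log units; beyond the scatter) the closer guide, although no measured compound carries 2-chloro-6-methylphenyl. No step beyond the scatter is therefore expected in this assay, and no direction can be called with confidence. The estimated step is a 1.3-fold lower number from compound 3 to compound 4 (0.13 log units; within the scatter). For compound 4 the estimated value is 45000 nM, with an expected range from 12000 nM to 150000 nM.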

Compound 4, half-maximal inhibitory concentration: 53600 nM
Compound 4: the middle estimate sits 1.2-fold (0.08 log units) below what was measured, and the stated range covers the measured number.
By their numbers in this assay, from the lowest: compound 1; then compounds 4 and 3 (each within the scatter of the next); then compound 2.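

In this assay there is a 1.1-fold lower number from compound 3 to compound 4 (0.05 log units; within the scatter) and so 2-chloro-6-methylphenyl cannot be told apart from 4-bromophenyl on this amide-type nitrogen, although the two groups share neither their halogen nor their substitution pattern. With a 12-fold higher number from compound 1 to compound 4 (1.07 log units; beyond the scatter) as a large step and a 2.7-fold lower number from compound 2 to compound 4 (0.43 log units; beyond the scatter) as a modest one, compound 1 now stands apart by a large step from all three other compounds, and its 4-fluoro-3-(trifluoromethyl)phenyl group is the only one of the four aryl groups to do so. Nothing available explains why these steps differ in size.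

As far as these compounds go, it remains open whether 4-fluorophenyl or 3-(trifluoromethyl)phenyl alone would give a number near that of compound 1 or near that of compound 4. How a pyridyl or a cyclohexyl ring would read at this nitrogen is open as well.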